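The source may report more compounds than this note shows. Statements on the series, on what has been measured and on what is new or still open speak of the compounds shown alone.

Measured compounds:

Compound 1, `COc1ccc(NS(=O)(=O)/C=C/c2c(F)c(F)c(F)c(F)c2F)cc1[N+](=O)[O-]`: 100000 nM
Compound 2, `COc1ccc(NS(=O)(=O)/C=C/c2c(F)c(F)c(F)c(F)c2F)cc1N`: 75000 nM
Compound 3, `COc1cc(OC)c(/C=C/S(=O)(=O)Nc2ccc(OC)c([N+](=O)[O-])c2)c(OC)c1`: 1000 nM

All three were tested in a functional assay on K562 cells (Homo sapiens) for cytotoxicity, read by trypan blue exclusion, with a stated time of 96 h; on this read-out lower numbers stand for stronger inhibition and higher numbers for weaker inhibition. In this assay compound 1 gives 100000 nM and compound 2 gives 75000 nM. These two share a core and differ in one place, (amino in place of nitro on an aromatic carbon); the step between them is a 1.3-fold lower number from compound 1 to compound 2 (0.12 log units; within the scatter), so nothing of weight separates them. Compound 3 is built on a different core; how the two cores differ is not broken down here. In this assay compound 3 gives 1000 nM, the lowest of the three numbers, with compound 2 the nearest and compound 1 the furthest, both gaps lying beyond the scatter.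

Compound 4, `COc1cc(OC)c(/C=C/S(=O)(=O)Nc2ccc(OC)c(N)c2)c(OC)c1`, has not been measured. It stands to compound 3 as compound 2 stands to compound 1: amino in place of nitro on an aromatic carbon. Since the two place descriptions match word for word, this is the same change, made on the other core. For the measured compounds named here, the only evidence for its effect is the step from compound 1 to compound 2, which stayed within the scatter. The step from compound 3 to compound 4 in this assay is therefore expected to be small, a 1.3-fold lower number from compound 3 to compound 4 (0.10 log units; within the scatter), because the matching step was a 1.3-fold lower number from compound 1 to compound 2 (0.12 log units; within the scatter). On that basis compound 4 is estimated at 800 nM, likely between 300 nM and 2500 nM.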

Compound 4, half-maximal inhibitory concentration: 3 nM
For compound 4 the middle estimate is 270-fold (2.43 log units) above the measured one; the whole stated range lies above it.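

In this assay, putting amino in place of nitro on an aromatic carbon of the core of compound 3 gives a large step: a 330-fold lower number from compound 3 to compound 4 (2.52 log units; beyond the scatter). The same swap on the core of compound 1 leaves the number almost where it was, so the size of this change did not carry over from one core to the other: the same change on two cores in this assay, a 1.3-fold lower number (0.12 log units; within the scatter) from compound 1 to compound 2 and a 330-fold lower number (2.52 log units; beyond the scatter) from compound 3 to compound 4, 250-fold (2.40 log units) apart, beyond the scatter of two such steps This shows that, in these two pairs, the result of the swap depends on the core that carries it, but it does not show which part of the core matters or why, and two pairs make no rule for any further core.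

The compounds shown carry only nitro or amino at this place, so it stays open how a plain hydrogen, a hydroxyl group or an acetamide would behave there on the core of compound 3, and whether the low number of compound 4 needs the amino group specifically. Also open, on these data alone, is which features of the core of compound 3 the large step relies on, and a compound that mixes features of the two cores while keeping the amino group would be needed to begin separating them.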